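This account rests on a few compounds, and the source may have more. Where it says the series, first, only, none or still open, it means among the compounds named here.

Measured so far:
- compound 1, `COc1cc(NCc2ccc(Cl)s2)ccc1-c1cnco1`: 43200 nM
- compound 2, `COc1ccc(CNc2ccc(-c3cnco3)c(OC)c2)cc1`: 41300 nM

In an ADME assay on Huh-7 cells (Homo sapiens) for cytotoxicity, read by MTT assay, with a stated time of 96 h (on this read-out higher numbers stand for lower toxicity in this test and lower numbers for higher toxicity in this test), compound 1 gives 43200 nM, the highest of the two numbers, though compound 2 gives 41300 nM and the gap between them lies within the scatter, so no order between the two can be read. Both sit in the same region of the read-out and the series has so far shown no step beyond the scatter.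

Compound 3, `COc1cc(NCc2scnc2C)ccc1-c1cnco1`, is not yet measured in this assay. Against compound 1 it differs by 4-methyl-1,3-thiazol-5-yl in place of 5-chlorothiophen-2-yl on a saturated chain carbon bound to a nitrogen on an aromatic ring. The shared core and the methoxy group are kept; only the group on the saturated chain carbon bound to the nitrogen on the aromatic ring changes.

Among the compounds with values here, with no measured step available as a guide, the step from compound 1 to compound 3 is expected to stay within the scatter, a 1.1-fold lower number from compound 1 to compound 3 (0.03 log units; within the scatter), in no particular direction. Compound 3 is therefore estimated at 40000 nM, with a range from 20000 nM to 80000 nM.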

Compound 3, half-maximal cytotoxic concentration: 58500 nM
Beside the measured number, compound 3's estimate is 1.5-fold (0.17 log units) below it; the range from low to high includes it.
By their numbers in this assay, from the lowest: compounds 2, 1 and 3 (each within the scatter of the next).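

In this assay, within the data shown here, the first measured step at this position, on a saturated chain carbon bound to a nitrogen on an aromatic ring, is a 1.4-fold higher number from compound 1 to compound 3 (0.13 log units; within the scatter) and so gives no order between the two compounds. Exchanging 5-chlorothiophen-2-yl for 4-methyl-1,3-thiazol-5-yl, a ring with 2 hetero atoms for one with 1 hetero atom, therefore produces no readable change in this test. No evidence on hand bears on this result.

The compounds shown carry only aromatic rings on the saturated chain carbon, so the read-out with a carboxylic acid, an amine or a longer chain there remains open. Whether any change at this position can move the number beyond the scatter also remains unsettled.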